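Swapping the group on the ring nitrogen of compound 3

This account rests on a few compounds, and the source may have more. Where it says the series, first, only, none or still open, it means among the compounds named here.

Values in a functional assay on Hep 3B2 cells (Homo sapiens) for inhibition, read by sulforhodamine B assay, with a stated time of 72 h (a higher number here means a weaker inhibitor, a lower number a stronger inhibitor), so far:
- Compound 1 `C[C@H](Nc1nc(N)nc(N)c1C#N)c1nn(-c2cccc(S(C)(=O)=O)c2)c2cc(F)ccc12` gives 19700 nM
- Compound 2 `C[C@H](Nc1ncnc2[nH]cnc12)c1nn(-c2cccnc2)c2cc(F)ccc12` gives 34500 nM
- Compound 3 `C[C@H](Nc1ncnc2[nH]cnc12)c1nn(-c2ccccn2)c2cc(F)ccc12` gives > 40000 nM as a limit

Compound 3 stands at the limit of > 40000 nM in this assay, at which 1 of the 3 values shown sits, and so has a limit, not a number. Compound 4 `C[C@H](Nc1ncnc2[nH]cnc12)c1nn(-c2cccc(S(C)(=O)=O)c2)c2cc(F)ccc12` carries 3-(methylsulfonyl)phenyl in place of pyridin-2-yl on an aromatic nitrogen and is otherwise the same. Going by the values given here, the only measured step at this place is an at least 1.1-fold higher number from compound 2 to compound 3 (0.06 log units; that floor lies within the scatter) and it offers little guidance. Compound 1 bears the same 3-(methylsulfonyl)phenyl but differs elsewhere, and compound 1 gives 19700 nM in this assay as the nearest clue. A small step of an at least 1.4-fold lower number from compound 3 to compound 4 (0.15 log units; that floor lies within the scatter) toward a lower number is therefore expected, and it may not clear the scatter. Compound 4 is expected near 28000 nM (estimated range 14000 nM to 40000 nM).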

Compound 4, half-maximal inhibitory concentration: 13000 nM
The estimate for compound 4 lay 2.2-fold (0.33 log units) above the measured number; measured number below the stated range.
By their numbers in this assay, from the lowest: compounds 4, 1 and 2 (each within the scatter of the next, the first and the last beyond it). At a limit, above all of these: compound 3.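

On the aromatic nitrogen, 3-(methylsulfonyl)phenyl gives a modest gain over both pyridine groups in this assay: the change brings a 2.7-fold lower number from compound 2 to compound 4 (0.42 log units; beyond the scatter), and also an at least 3.0-fold lower number from compound 3 to compound 4 (0.48 log units; beyond the scatter). The second step is only a floor, since compound 3 has a limit and not a number: the limit of > 40000 nM in this assay, at which 1 of the 4 values shown sits. With 3-(methylsulfonyl)phenyl in place, changing the group on the amine nitrogen brings a 1.5-fold lower number from compound 1 to compound 4 (0.18 log units; within the scatter), so the two groups there cannot be told apart.

On these data alone, it remains open whether the methylsulfonyl group itself matters. A plain phenyl, or a phenyl carrying an amine or a carboxylic acid instead, could answer that.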